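The source may hold more compounds than are shown below. What is called first, only, known or untested is meant among the compounds shown, and "the series" means these compounds.

Working notes on the series in an assay on HEK293 cells for inhibition of kynurenine 3-monooxygenase (Homo sapiens), read by LC-MS, with a stated time of 20 h; on this read-out lower numbers stand for stronger inhibition and higher numbers for weaker inhibition. Compound 1 `C[C@@H](Oc1cc2oc(=O)n(CCC(=O)O)c2cc1Cl)c1cccnn1` gives 631 nM. Compound 2 `O=C(O)CCn1c(=O)oc2cc(Cl)c(Cl)cc21`, which carries no ether substituent, gives 2000 nM. Compound 3 `Cc1cccc([C@@H](C)Oc2cc3oc(=O)n(CCC(=O)O)c3cc2Cl)n1` gives 316 nM, the lowest of the three numbers; the gap to compound 2 lies beyond the scatter, while a 2.0-fold lower number from compound 1 to compound 3 (0.30 log units; within the scatter).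

Compound 4 `C[C@@H](Oc1cc2oc(=O)n(CCC(=O)O)c2cc1Cl)c1ncco1` is to be measured. Relative to compound 3 the change is 1,3-oxazol-2-yl in place of 6-methylpyridin-2-yl on a saturated chain carbon bound to an oxygen on an aromatic ring and a saturated chain carbon. For the measured compounds named here, the only step that bears on it is the one from compound 1 to compound 3, which shows that exchanging one aromatic group on that saturated chain carbon for another moved the number by a 2.0-fold lower number from compound 1 to compound 3 (0.30 log units; within the scatter). A shift of similar size, toward a higher number, is expected for compound 4, that is a 2.5-fold higher number from compound 3 to compound 4 (0.40 log units; beyond the scatter). Compound 4 is estimated at 800 nM, in the range 300 nM to 2500 nM.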

Compound 4, half-maximal inhibitory concentration in the kynurenine 3-monooxygenase assay: 7940 nM
For compound 4 the middle estimate is 9.9-fold (1.00 log units) below the measured one; the whole stated range lies below it.
By their numbers in the kynurenine 3-monooxygenase assay, from the lowest: compounds 3 and 1 (each within the scatter of the next); then compound 2; then compound 4.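

On this saturated chain carbon the aromatic group matters far more than the earlier pair suggested: in the kynurenine 3-monooxygenase assay the exchange gives a 25-fold higher number from compound 3 to compound 4 (1.40 log units; beyond the scatter) and a 13-fold higher number from compound 1 to compound 4 (1.10 log units; beyond the scatter). An ether substituent is no gain in itself, since in the kynurenine 3-monooxygenase assay replacing one chlorine atom gives a 4.0-fold higher number from compound 2 to compound 4 (0.60 log units; beyond the scatter). In a physicochemical assay for lipophilicity, read by HPLC, at pH 7.4 (on this read-out higher numbers stand for higher lipophilicity and lower numbers for lower lipophilicity), compound 3 gives 2.12 and compound 4 gives 1.11, so the weaker inhibition comes with lower lipophilicity: the measured distribution coefficient of compound 3, 2.12, and of compound 4, 1.11, a number 1.01 log units lower (beyond the scatter)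

The compounds shown do not separate ring size and hetero atoms from the distribution coefficient. Going by these compounds, how a 1,3-thiazol-2-yl or a phenyl group would behave on that carbon remains open.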